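Chloro in Place of Trifluoromethyl on a Shared Core

The compounds below may be only part of what the source reports. "The series", "measured", "known", "first", "only" and "open" are said of these compounds alone.

Two compounds of this series have been examined in an assay on COS-7 cells for inhibition of Fatty-acid amide hydrolase 1 (Homo sapiens), read by scintillation counting, with a stated time of 10 min, tested at 10 uM; on this read-out lower numbers stand for less inhibition and higher numbers for more inhibition at the one concentration tested (going by the name of the read-out). Compound 1 `COc1nn(Cc2cccc(NC(C)=O)c2)c(=O)o1` is recorded there as "not active" (no number reported), with no number given for it. Compound 2 `COc1nn(Cc2cccc(C(F)(F)F)c2)c(=O)o1` gives 12% in this assay, which is the only number shown for the series; the one further entry, compound 1, carries no single number at all. Compound 2 therefore stands alone as the sole measured point of reference.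

Compound 3 `COc1nn(Cc2cccc(Cl)c2)c(=O)o1` differs from compound 2 in one place: chloro in place of trifluoromethyl on an aromatic carbon. Within the data shown here, no step between two measured compounds has been reported, so there is nothing to say how large a change of this kind should be in this assay.

Given that compound 2 gives 12%, the author expects compound 3 to land in the same low region, with a step of a number 2 percentage points lower from compound 2 to compound 3 (within the scatter) that does not reach beyond the usual scatter. Compound 3 is estimated at 10% in this assay, within a range from 0% to 25%.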

Compound 3, a percentage reported as inhibition, at one concentration (the size of the read-out at that concentration, not a potency): 37%
The estimate for compound 3 lay 27 percentage points below the measured number; the measured number lies above the stated range.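

In this assay, among these compounds, chloro in place of trifluoromethyl on the aromatic carbon gives a step of a number 25 percentage points higher from compound 2 to compound 3 (beyond the scatter), the first step that can be read, and it shows that the read-out responds to the group held at this position. By the computed counts, the entering chloro has 1 heavy atom where trifluoromethyl has 4, while both have 0 hydrogen-bond donors and 0 hydrogen-bond acceptors, so the step comes with a change in heavy-atom count and none in those two counts. No measurement at hand accounts for the step, so its cause remains unassigned.

Going by these compounds, a single exchange cannot show whether the read-out follows any trend across groups at this position, and it remains open what a bromine, a methyl or an amine on the same aromatic carbon would give. Among the compounds shown here, compound 1 carries no number, so no step involving it can be read, and whether chloro would give a similar step on another core also stays unanswered.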